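Methyl on the amide nitrogen of compound 3

The compounds below may be only part of what the source reports. "The series", "measured", "known", "first", "only" and "open" are said of these compounds alone.

Values in an ADME assay on S9 fraction from liver (Homo sapiens) for metabolic stability, with a stated time of 1 h; on this read-out lower numbers stand for a less stable compound and higher numbers for a more stable compound:
- compound 1 `N#Cc1cnc(NCc2cnccc2C(F)(F)F)cc1NC[C@H]1C[C@H](O)C1`: 93%
- compound 2 `CO[C@H]1CC[C@@H](CNc2cc(NCc3cnccc3C(F)(F)F)ncc2C#N)CC1`: 4%
- compound 3 `N#Cc1cnc(NCc2cnccc2C(F)(F)F)cc1N[C@H]1CC[C@@H](C(N)=O)CC1`: 90%

At the top of this small set, compound 3 at 90% cannot be separated from compound 1, with a number 3 percentage points lower from compound 1 to compound 3 (within the scatter). It stands far from compound 2, with a number 86 percentage points higher from compound 2 to compound 3 (beyond the scatter).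

The next compound is compound 4 `CNC(=O)[C@H]1CC[C@@H](Nc2cc(NCc3cnccc3C(F)(F)F)ncc2C#N)CC1`. It differs from compound 3 by methyl in place of hydrogen on an amide-type nitrogen, which turns 4-carbamoylcyclohexyl into 4-(methylcarbamoyl)cyclohexyl.

Within the data shown here, no measured step makes this exact change, so the evidence is indirect. The two large steps, a number 89 percentage points lower from compound 1 to compound 2 (beyond the scatter) and a number 86 percentage points higher from compound 2 to compound 3 (beyond the scatter), show how far this assay can move within this series when the group on the aromatic nitrogen changes. Both are much larger changes than a single added methyl, so they serve as a warning and not as a measure. Compound 2 is the only low reader so far, and nothing yet shows how an amide substituent behaves.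

A moderate drop is expected, estimated as a number 15 percentage points lower from compound 3 to compound 4 (beyond the scatter), though a result within the scatter remains possible. For compound 4 the estimated value is 75%, with an expected range from 45% to 95%.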

Compound 4, percent of the compound remaining: 71%
Estimate against measurement, compound 4: 4 percentage points above; measured number inside the range.
By their numbers in this assay, from the lowest: compound 2; then compound 4; then compounds 3 and 1 (each within the scatter of the next).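

In this assay, among these compounds, the amide nitrogen of the 4-carbamoylcyclohexyl group turns out not to be a neutral place for substitution: methyl in place of hydrogen on this amide-type nitrogen gives a number 19 percentage points lower from compound 3 to compound 4 (beyond the scatter), the first reading of any change at this position and a modest one. The 4-(methylcarbamoyl)cyclohexyl group still reads far from the low end of this small set, with a number 67 percentage points higher from compound 2 to compound 4 (beyond the scatter), but it no longer sits level with the top, with a number 22 percentage points lower from compound 1 to compound 4 (beyond the scatter), so the amide substituent lands in an intermediate place that the earlier values did not occupy. Nothing measured here accounts for the lower number with the added methyl.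

Going by these compounds, a single matched pair speaks to this nitrogen, so it remains open whether the number keeps falling with a longer chain such as ethyl on the amide nitrogen, or with a second substituent there as in a dimethylcarbamoyl group. Also open, on these data alone, is how a carboxylic acid in place of the carbamoyl group would read on the same cyclohexyl ring.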